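Arylsulfonyl series: exchanging the amine-linked bicycle

The source may hold more compounds than are shown below. What is called first, only, known or untested is meant among the compounds shown, and "the series" means these compounds.

Within a functional assay on K562 cells (Homo sapiens) for inhibition, read by trypan blue exclusion, with a stated time of 72 h (a higher number here means a weaker inhibitor, a lower number a stronger inhibitor), compound 1 `Cn1c(=O)c(S(=O)(=O)c2ccc(F)cc2)cc2cnc(Nc3cnc4[nH]ccc4c3)nc21` gives 750 nM, the lowest of the three numbers measured so far. Compound 3 `Cn1c(=O)c(S(=O)(=O)c2ccc(Cl)cc2)cc2cnc(Nc3cnc4[nH]ccc4c3)nc21` gives 5000 nM and compound 2 `Cc1ccc(S(=O)(=O)c2cc3cnc(Nc4cnc5[nH]ccc5c4)nc3n(C)c2=O)cc1` gives 15000 nM. Among the measured compounds shown here, all of the measured steps sit on the sulfonyl-bearing aromatic ring: a 6.7-fold higher number from compound 1 to compound 3 (0.82 log units; beyond the scatter), a 20-fold higher number from compound 1 to compound 2 (1.30 log units; beyond the scatter) and a 3.0-fold lower number from compound 2 to compound 3 (0.48 log units; beyond the scatter).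

Compound 4 `Cn1c(=O)c(S(=O)(=O)c2ccc(F)cc2)cc2cnc(Nc3ccc4[nH]ccc4c3)nc21` keeps the fluoro-bearing ring of compound 1 unchanged and differs only at the amine-linked bicycle: a group of 9 heavy atoms (8 carbon, 1 nitrogen; one five-membered aromatic ring with 1 hetero atom, one six-membered aromatic ring of carbon only) in place of a group of 9 heavy atoms (7 carbon, 2 nitrogen; one five-membered aromatic ring with 1 hetero atom, one six-membered aromatic ring with 1 hetero atom), on a nitrogen on an aromatic ring. For the measured compounds named here, none of the measured steps touches this part of the molecule, so none bears directly on the change, and the series offers no measured guide to how the number responds when the six-membered aromatic ring with 1 hetero atom becomes a six-membered aromatic ring of carbon only. The step in this assay is therefore open in both size and direction. Going by the values given here, for compound 4 a moderate loss is taken as the working expectation, held loosely and with a wide range because there is no precedent among the three measured compounds, the expected step being a 2.4-fold higher number from compound 1 to compound 4 (0.38 log units; beyond the scatter). Compound 4 is estimated at 1800 nM, with a range from 300 nM to 10000 nM.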

Compound 4, half-maximal inhibitory concentration: 200 nM
Compound 4: middle estimate off by 9.0-fold (0.95 log units), on the high side; the measured number lies below the stated range.
By their numbers in this assay, from the lowest: compound 4; then compound 1; then compound 3; then compound 2.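

In this assay, among the compounds shown here, the amine-linked bicycle proves to be a second position that moves the number, and this is the first measured change away from the sulfonyl-bearing aromatic ring. Placing 1H-indol-5-yl on the nitrogen gives a 3.8-fold lower number from compound 1 to compound 4 (0.57 log units; beyond the scatter), a drop in the number, whereas both changes to the fluoro-bearing ring of compound 1 raised it. For this pair, the six-membered aromatic ring of carbon only is clearly tolerated, and the hydrogen-bond acceptor counted in the leaving group is not needed for a lower number, though no measurement shown here accounts for the step.

On these data alone, it remains open whether 1H-indol-5-yl would give a similar step with chloro or methyl on the sulfonyl-bearing ring, so the two positions cannot yet be treated as independent. Also open, as far as these compounds go, is how the number responds when the bicycle gives way to a single ring such as phenyl, or when 1H-indol-5-yl carries an added group such as an amine or a carboxylic acid.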